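A few compounds are considered here, and "the series" means these few. Any claim that something is new, unique, unknown or untested is made for them only; others in the source may bear on it.

Measured so far:
- compound 1 `N#Cc1ccc(O[C@H]2CN(S(=O)(=O)c3ccc(C(F)(F)F)cc3)C[C@@]2(O)CO)cc1F`: 0.033
- compound 2 `N#Cc1ccc(O[C@H]2CN(S(=O)(=O)c3ccc(Cl)cn3)C[C@@]2(O)CO)cc1F`: 0.18

Both compounds share one core and differ only in the group on the sulfonyl sulfur. Within the data shown here, in an ADME assay on a cell-free system (plasma, Rattus norvegicus) for protein binding (a lower number here means a smaller unbound share, a higher number a larger unbound share of the compound), compound 2 gives 0.18, the higher of the two numbers; the one step measured, a 5.5-fold higher number from compound 1 to compound 2 (0.74 log units; beyond the scatter), separates it from compound 1, which gives 0.033 in this assay.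

Compound 3 `N#Cc1ccc(O[C@H]2CN(S(=O)(=O)c3ccc(Cl)cn3)C[C@@]2(O)CN)cc1F` is not yet measured. It differs from compound 2 in one place: amino in place of hydroxy on a saturated chain carbon bound to a saturated ring carbon. Among the measured compounds shown here, the only measured step, a 5.5-fold higher number from compound 1 to compound 2 (0.74 log units; beyond the scatter), concerns a change on the sulfonyl sulfur, not on the saturated chain carbon; nothing measured here touches the place where compound 3 changes. For the measured compounds named here, there is thus no step to lean on, and the change swaps one donor-acceptor group for another of the same count. The expectation is a small shift at most, probably within the scatter, with the unbound fraction of compound 3 somewhat above that of compound 2 if anything: a 1.6-fold higher number from compound 2 to compound 3 (0.19 log units; within the scatter). Compound 3 is estimated at 0.28, with a range from 0.13 to 0.55.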

Compound 3, unbound fraction: 0.14
Compound 3: middle estimate off by 2.0-fold (0.30 log units), on the high side; the measured number falls inside the stated range.
By their numbers in this assay, from the lowest: compound 1; then compounds 3 and 2 (each within the scatter of the next).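

In this assay, amino in place of hydroxy on a saturated chain carbon bound to a saturated ring carbon gives a 1.3-fold lower number from compound 2 to compound 3 (0.11 log units; within the scatter), so with 5-chloropyridin-2-yl on the sulfonyl sulfur, hydroxymethyl and aminomethyl cannot be told apart in this read-out. Among these compounds, this is the first reading at this place, and it differs from the step on the sulfonyl sulfur, a 5.5-fold higher number from compound 1 to compound 2 (0.74 log units; beyond the scatter): of the two places varied in these three compounds, only the sulfonyl sulfur shows a step beyond the scatter. No measurement is available that bears on the outcome at the saturated chain carbon.

On these data alone, whether amino and hydroxy also stay within the scatter of each other with 4-(trifluoromethyl)phenyl on the sulfonyl sulfur remains open, since this step has been read with 5-chloropyridin-2-yl only. The compounds shown carry only hydroxy and amino at this place, so the effect on the unbound fraction of a carboxylic acid, a methoxy group or a longer chain there also remains open.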